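The compounds below may be only part of what the source reports. "The series", "measured", "known", "first", "only" and "open" are said of these compounds alone.

Compound 1 `N#Cc1ccc(Cn2c(/C=C3\SC(=S)N(CC(=O)O)C3=O)nc3ccccc32)cc1`: 26600 nM
Compound 2 `O=C(O)CN1C(=O)/C(=C/c2nc3ccccc3n2Cc2ccc(F)cc2)SC1=S`: 3570 nM
Compound 3 `Cc1ccc(Cn2c(/C=C3\SC(=S)N(CC(=O)O)C3=O)nc3ccccc32)cc1`: 3220 nM

All three values come from a functional assay on A549 cells (Homo sapiens) for cytotoxicity, read by MTT assay, with a stated time of 48 h; a lower number here means a stronger inhibitor, a higher number a weaker inhibitor. Compound 3, at 3220 nM, has the lowest number of the three, but it cannot be separated from compound 2: a 1.1-fold lower number from compound 2 to compound 3 (0.04 log units; within the scatter), within the scatter. Only compound 1 stands apart, as an 8.3-fold lower number from compound 1 to compound 3 (0.92 log units; beyond the scatter) shows.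

Compound 4 `CCn1c(/C=C2\SC(=S)N(CC(=O)O)C2=O)nc2ccccc21` carries this change: methyl in place of 4-methylphenyl on a saturated chain carbon bound to an aromatic nitrogen. Cut one bond further out, this reads 4-methylbenzyl to ethyl, so the aromatic ring is lost.

Going by the values given here, the measured steps bear on this only indirectly. a 7.5-fold lower number from compound 1 to compound 2 (0.87 log units; beyond the scatter) and an 8.3-fold lower number from compound 1 to compound 3 (0.92 log units; beyond the scatter) are modest and beyond the scatter, but they only exchange a group on an aromatic carbon, and no measured compound lacks the ring. The size of this step is therefore poorly constrained, and a move to a higher number in this assay is expected, of at least modest size. The expected step is a 3.1-fold higher number from compound 3 to compound 4 (0.49 log units; beyond the scatter). For compound 4 the estimated value is 10000 nM, with an expected range of 3000 nM to 40000 nM.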

Compound 4, half-maximal inhibitory concentration: 9440 nM
Beside the measured number, compound 4's estimate is 1.1-fold (0.03 log units) above it; measured number inside the range.
By their numbers in this assay, from the lowest: compounds 3 and 2 (each within the scatter of the next); then compound 4; then compound 1.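

In this assay the ring-bearing groups on the saturated chain carbon bound to an aromatic nitrogen do not act alike when replaced by methyl: the changes from 4-methylphenyl and 4-fluorophenyl give a 2.9-fold higher number from compound 3 to compound 4 (0.47 log units; beyond the scatter) and a 2.6-fold higher number from compound 2 to compound 4 (0.42 log units; beyond the scatter) respectively read as rises, whereas the change from 4-cyanophenyl gives a 2.8-fold lower number from compound 1 to compound 4 (0.45 log units; beyond the scatter) as a fall. Loss of the aromatic ring therefore has no single direction across these compounds, with compound 1 going against the rise seen for compound 2 and compound 3, and the ethyl compound 4 sits between the two levels. No measured data bear on the reason for this split.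

Open, from the compounds shown here alone, is how a plain unsubstituted benzyl would fall relative to the ethyl of compound 4. Also open, going by these compounds, is whether a longer chain such as butyl, or an amine at the end of such a chain, would hold the lower numbers without any aromatic ring.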